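Acetyl in Place of Hydroxyl Hydrogen on a Naphthalene Enediyne

A few compounds are considered here, and "the series" means these few. Any claim that something is new, unique, unknown or untested is made for them only; others in the source may bear on it.

Compound 1, `OC1C#CCCCCC#C/C1=C\c1cccc2ccccc12`: 41000 nM
Compound 2, `OC1C#CCCCCC#C/C1=C\c1ccc2ccccc2c1`: 3600 nM
Compound 3, `COc1ccc(/C=C2\C#CCCCCC#CC2O)cc1`: 5800 nM

All three were tested in a functional assay on P388 cells (Mus musculus) for inhibition, read by MTT assay; a lower number here means a stronger inhibitor, a higher number a weaker inhibitor. Compound 1 gives the highest number of the three and is thus the weakest inhibitor here; compound 3 gives a lower number and compound 2 a lower one still, and both gaps lie beyond the usual scatter. Compound 4, `CC(=O)OC1C#CCCCCC#C/C1=C\c1cccc2ccccc12`, differs from compound 1 in one place: acetyl in place of hydrogen on an oxygen on a saturated carbon. Going by the values given here, no measured pair shows what this change does in this assay, so the expectation rests on the change alone. The expected step, a 1.4-fold lower number from compound 1 to compound 4 (0.14 log units; within the scatter), is small, a modest move toward a lower number that may well lie within the scatter. Compound 4 is therefore expected to give about 30000 nM in this assay, within a range of 8000 nM to 120000 nM.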

Compound 4, half-maximal inhibitory concentration: 2400 nM
Estimate against measurement, compound 4: 13-fold (1.10 log units) above; measured number outside the range, below it.
By their numbers in this assay, from the lowest: compounds 4, 2 and 3 (each within the scatter of the next, the first and the last beyond it); then compound 1.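

This position is far from neutral. In this assay, hydroxy to acetoxy on the core of compound 1 brings a large change (a 17-fold lower number from compound 1 to compound 4 (1.23 log units; beyond the scatter)), so a free hydroxy group is not required for inhibition in this series. No available evidence explains why the step is so large.

On these data alone, it remains open whether a longer ester such as benzoyl, a methyl ether or an amine at this carbon would act like acetoxy. Whether acetyl brings a similar step on compound 2 or compound 3 is also unknown.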